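Toward a Morpholine Amide: Expected Lipophilicity of Compound 3

The source may report more compounds than this note shows. Statements on the series, on what has been measured and on what is new or still open speak of the compounds shown alone.

Measured so far:
compound 1, `CC[C@H](C)[C@H](NC(=O)[C@H](CC(=O)O)NC(=O)CCCOc1ccc(C(=N)N)cc1)C(=O)O`, 1.47
compound 2, `CC(C)(C)CC(NC(=O)C(CC(=O)O)NC(=O)CCCOc1ccc(C(=N)N)cc1)C(=O)O`, 1.59

In a physicochemical assay for lipophilicity (a lower number here means a more polar compound, a higher number a more lipophilic compound), compound 1 gives 1.47, the lower of the two numbers recorded, while compound 2 gives 1.59. The gap between them lies within the usual scatter of this assay, so the two compounds cannot be told apart on these numbers.

Compound 3, `CC(C)[C@H](NC(=O)[C@H](CC(=O)O)NC(=O)CCCOc1ccc(C(=N)N)cc1)C(=O)N1CCOCC1`, has not yet been measured. Compared with compound 1 it carries 2-methyl-1-((morpholin-4-yl)carbonyl)propyl in place of 1-carboxy-2-methylbutyl on an amide-type nitrogen. A hydrogen-bond donor is removed and one acceptor is gained, and the fragment that enters is larger than the one that leaves. Among the compounds with values here, no comparable step between measured compounds is available, so the expectation rests on the structural change alone.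

Compound 3 is expected to come out higher than compound 1 in this assay, by a step of a number 0.83 log units higher from compound 1 to compound 3 (beyond the scatter), which would lie beyond the scatter. The estimate for compound 3 is 2.3, with a range from 1.6 to 3.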

Compound 3, partition coefficient: 0.716
The estimate for compound 3 lay 1.58 log units above the measured number; measured number outside the range, below it.
By their numbers in this assay, from the lowest: compound 3; then compounds 1 and 2 (each within the scatter of the next).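

Swapping 1-carboxy-2-methylbutyl for 2-methyl-1-((morpholin-4-yl)carbonyl)propyl on an amide-type nitrogen gives the first shift in this set that clears the scatter in this assay, with a number 0.75 log units lower from compound 1 to compound 3 (beyond the scatter), whereas the numbers of compound 1 and compound 2 could not be told apart. The direction is not what simple counting might suggest: the entering group is the larger, with 12 heavy atoms against 8, and it has 0 hydrogen-bond donors against 1, yet the number falls, so for this pair neither count sets the direction. Nothing measured here explains the fall.

This single step changes several things at once, as the carboxylic acid gives way to the morpholine amide while the side chain also changes from 2-methylbutyl to 2-methylpropyl, so the compounds shown cannot say which part accounts for the shift. On these data alone, a methyl ester or a primary amide at this place, carried on the same side chain as compound 1, would be one way to pull these parts apart, and how either would read in this assay remains open.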